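The source may hold more compounds than are shown below. What is called first, only, known or untested is meant among the compounds shown, and "the series" means these compounds.

Compound 1 `Cn1nc2c(=O)n(CC3(O)CCN(Cc4ccc(-c5ccco5)cc4Cl)CC3)cnc2c1-c1ccc(CNC(=O)C(F)(F)F)cc1` gives 2060 nM in an assay on isolated protein for inhibition of ubiquitin carboxyl-terminal hydrolase 7 (Homo sapiens), with stated times of 30 min and 2 h (a higher number here means a weaker inhibitor, a lower number a stronger inhibitor), the highest of the three numbers measured. For the measured compounds named here, compound 2 `Cn1nc2c(=O)n(CC3(O)CCN(Cc4ccc(C5=CCCC5)cc4Cl)CC3)cnc2c1-c1ccc(CN)cc1` gives 76.9 nM and compound 3 `Cn1nc2c(=O)n(CC3(O)CCN(Cc4ccc(-c5cccs5)cc4Cl)CC3)cnc2c1-c1ccc(CN)cc1` gives 38.6 nM in this assay; the only single-place step among them, a 2.0-fold lower number from compound 2 to compound 3 (0.30 log units; within the scatter), concerns the aryl substituent and does not bear on the change now followed. Compound 4 `Cn1nc2c(=O)n(CC3(O)CCN(Cc4ccc(-c5ccco5)cc4Cl)CC3)cnc2c1-c1ccc(CO)cc1` differs from compound 1 by hydroxy in place of ((trifluoromethyl)carbonyl)amino on a saturated chain carbon bound to an aromatic carbon. Going by the values given here, no measured step covers this change; compounds 2 and 3, which carry an aminomethyl group, simply show far lower numbers than compound 1. Compound 4 is therefore expected to give an intermediate number, 600 nM with a range of 150 nM to 2500 nM, that is a 3.4-fold lower number from compound 1 to compound 4 (0.54 log units; beyond the scatter).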

Compound 4, half-maximal inhibitory concentration: 42.5 nM
For compound 4 the middle estimate is 14-fold (1.15 log units) above the measured one, outside the stated range (below it).
By their numbers in this assay, from the lowest: compounds 3, 4 and 2 (each within the scatter of the next); then compound 1.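

In this assay, hydroxy in place of ((trifluoromethyl)carbonyl)amino on a saturated chain carbon bound to an aromatic carbon gives a 48-fold lower number from compound 1 to compound 4 (1.69 log units; beyond the scatter). For the compounds shown here, this is the first single-place step at this position, and it shows that the group held there can move the number well beyond the scatter, which the earlier step on the aryl substituent did not. Nothing available explains the size of this step. Still open, as far as these compounds go, is how an amine, a carboxylic acid or a longer chain at this place would compare with hydroxy, with the rest of compound 4 unchanged.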